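Changing the Group on an Aromatic Nitrogen

The compounds below may be only part of what the source reports. "The series", "measured", "known", "first", "only" and "open" are said of these compounds alone.

Of the compounds shown here, three sharing one core have been tested in a functional assay on SH-SY5Y cells (Homo sapiens) for cytotoxicity, read by MTT assay, with a stated time of 72 h; a lower number here means a stronger inhibitor, a higher number a weaker inhibitor. Compound 1 `CN1CCN(CCCCCn2c3c(c4ccccc42)C(=O)c2c[n+]([O-])c4ccccc4c2C3=O)CC1` carries a 5-(4-methylpiperazin-1-yl)pentyl chain on an aromatic nitrogen, and in this assay compound 1 gives 830 nM. Compound 3 `O=C1c2c[n+]([O-])c3ccccc3c2C(=O)c2[nH]c3ccccc3c21` has hydrogen in that place instead; in this assay compound 3 gives 1380 nM. The step of a 1.7-fold higher number from compound 1 to compound 3 (0.22 log units; within the scatter) shows that removing this chain changes little. Compound 2 `CC1(C)O[C@@H](CO)[C@H](Cn2cc(Cn3c4c(c5ccccc53)C(=O)c3c[n+]([O-])c5ccccc5c3C4=O)nn2)O1` bears a (5-(hydroxymethyl)-2,2-dimethyl-1,3-dioxolan-4-yl)methyl group on an aromatic nitrogen of a five-membered aromatic ring with 3 nitrogen. For compound 2, this assay reports only a limit, > 1000 nM, which is the point described by the limit of > 1000 nM in this assay, at which 1 of the 3 values shown sits. Compound 4 `O=C1c2c[n+]([O-])c3ccccc3c2C(=O)c2c1c1ccccc1n2Cc1cn([C@@H]2C[C@H](O)[C@@H](CO)O2)nn1` differs from compound 2 in one place: 4-hydroxy-5-(hydroxymethyl)oxolan-2-yl in place of (5-(hydroxymethyl)-2,2-dimethyl-1,3-dioxolan-4-yl)methyl on an aromatic nitrogen. Among the compounds with values here, no measured step covers this change, and the only measured step, a 1.7-fold higher number from compound 1 to compound 3 (0.22 log units; within the scatter), concerns a different position and lies within the scatter. Compound 2 itself sits at the limit, so for compound 4 a number near or beyond that limit is expected. The step that the limit leaves unreadable from compound 2 to compound 4 is expected to be small. Compound 4 is estimated at 1500 nM, with a range from 600 nM to 4000 nM.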

Compound 4, half-maximal inhibitory concentration: 150 nM
For compound 4 the middle estimate is 10-fold (1.00 log units) above the measured one; measured number outside the range, below it.
By their numbers in this assay, from the lowest: compound 4; then compounds 1 and 3 (each within the scatter of the next).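

Replacing (5-(hydroxymethyl)-2,2-dimethyl-1,3-dioxolan-4-yl)methyl with 4-hydroxy-5-(hydroxymethyl)oxolan-2-yl on an aromatic nitrogen of the five-membered aromatic ring with 3 nitrogen gives, in this assay, an at least 6.6-fold lower number from compound 2 to compound 4 (0.82 log units; beyond the scatter). Within the data shown here, this is the first step to lie beyond the scatter, so the number in this assay does respond to the group at this position, which the earlier step, at a different position, could not show. The size of the step is only a minimum because the value for compound 2 is a limit and not a number: the limit of > 1000 nM in this assay, at which 1 of the 4 values shown sits.

The change alters several features at once, including the ring, the number of hydrogen-bond donors and the stereocentres, so the compounds shown cannot tell which of these matters. From the compounds shown here alone, it also remains open how an amine, a carboxylic acid or a simple longer chain at this position would compare.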